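Estimating clearance after one ring swap

The source may hold more compounds than are shown below. What is called first, only, known or untested is meant among the compounds shown, and "the series" means these compounds.

In an ADME assay on the whole organism for pharmacokinetics, with Rattus norvegicus as the target (on this read-out lower numbers stand for slow clearance and higher numbers for fast clearance), compound 1 `COc1ccc(C(=O)C2=C(O)C(=O)N(c3ccc(-c4noc(C)n4)cc3)C2C2CCCCC2)cc1` gives 5 mL/min/kg and compound 2 `COc1ccc(C(=O)C2=C(O)C(=O)N(c3ccc(-c4nnc(C)o4)cc3)C2C2CCCCC2)cc1` gives 5.5 mL/min/kg on the same core, two values within the usual scatter of each other. Compound 3 `COc1ccc(C(=O)C2=C(O)C(=O)N(c3ccc(-c4ncco4)cc3)C2C2CCCCC2)cc1` stands at "not determined" (no result reported) in this assay and so offers no number to start from. Compound 4 `COc1ccc(C(=O)C2=C(O)C(=O)N(c3ccc(-c4cc(C)no4)cc3)C2C2CCCCC2)cc1` keeps that core and changes one group, with 3-methyl-1,2-oxazol-5-yl in place of 1,3-oxazol-2-yl on an aromatic carbon, para to a large group (3-methyl-1,2-oxazol-5-yl in place of 1,3-oxazol-2-yl on an aromatic carbon). Among the compounds with values here, only one measured step bears on this swap: a 1.1-fold higher number from compound 1 to compound 2 (0.04 log units; within the scatter) lies within the scatter, and there 5-methyl-1,3,4-oxadiazol-2-yl took the place of 5-methyl-1,2,4-oxadiazol-3-yl on an aromatic carbon. A single step is thin evidence, so the range stays wide, but no shift beyond the scatter is expected from the level of compounds 1 and 2. For compound 4 the clearance in this assay is expected near 6 mL/min/kg (from 3 mL/min/kg to 14 mL/min/kg).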

Compound 4, clearance: 6.2 mL/min/kg
The estimate for compound 4 lay 1.0-fold (0.01 log units) below the measured number; low and high end bracket the measured number.
By their numbers in this assay, from the lowest: compounds 1, 2 and 4 (each within the scatter of the next).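

In this assay the level seen so far is not limited to the two methyl-oxadiazole rings: a 1.1-fold higher number from compound 2 to compound 4 (0.05 log units; within the scatter) and a 1.2-fold higher number from compound 1 to compound 4 (0.09 log units; within the scatter). A third methyl-bearing five-membered aromatic ring, 3-methyl-1,2-oxazol-5-yl, therefore fits on this aromatic carbon, para to a large group, and all three rings give values within the scatter of one another. No measurement shown here explains why these rings read alike.

Going by these compounds, compound 3 has no number, so steps to or from it cannot be read, and what the methyl group contributes on such a ring remains unknown. On these data alone, whether an amine or a carboxylic acid on this same aromatic carbon would stay at this level of clearance also remains open.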